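The source may report more compounds than this note shows. Statements on the series, on what has been measured and on what is new or still open speak of the compounds shown alone.

Four compounds share a chain with a triple bond, carrying a variable group at one end. Compound 1 `CC1CCC(=O)N1CC#CCn1ccnc1` bears a 1H-imidazol-1-yl group on a saturated chain carbon bound to a triple-bonded carbon. In a functional assay on the whole organism for agonist activity, with Mus musculus as the target (on this read-out lower numbers stand for an effect already at smaller amounts and higher numbers for an effect only at larger amounts of compound), compound 1 gives only a limit, > 100 mg/kg, and no number. Compound 2 `CC1CCC(=O)N1CC#CCN(C)C` differs from it by dimethylamino in place of 1H-imidazol-1-yl on a saturated chain carbon bound to a triple-bonded carbon; in this assay compound 2 gives 3.7 mg/kg. The step is an at least 27-fold lower number from compound 1 to compound 2 (1.43 log units; beyond the scatter), and it is measured against (the limit of > 100 mg/kg in this assay, at which 1 of the 3 values shown sits), so its true size could be larger still. Compound 3 `COC(=O)N(C)CC#CCn1ccnc1` keeps the 1H-imidazol-1-yl group on a different core; how its core differs from that of compound 1 is not broken down here. In this assay compound 3 gives 4.5 mg/kg, which sits within the scatter of compound 2. Compound 4 `COC(=O)N(C)CC#CCN(C)C` is not yet measured and differs from compound 3 by dimethylamino in place of 1H-imidazol-1-yl on a saturated chain carbon bound to a triple-bonded carbon, the same change at the same place as before. That change gave an at least 27-fold lower number from compound 1 to compound 2 (1.43 log units; beyond the scatter). On that basis a step of a 23-fold lower number from compound 3 to compound 4 (1.35 log units; beyond the scatter) is expected from the same change. For compound 4 a value of 0.2 mg/kg is estimated, with a range from 0.05 mg/kg to 0.8 mg/kg.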

Compound 4, dose for half-maximal effect: 9.7 mg/kg
Beside the measured number, compound 4's estimate is 49-fold (1.69 log units) below it; the measured number lies above the stated range.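

In this assay, putting dimethylamino in place of 1H-imidazol-1-yl gives a 2.2-fold higher number from compound 3 to compound 4 (0.33 log units; beyond the scatter), so the large drop in the number seen on the core of compound 1 does not reappear on the core of compound 3. This change therefore cannot be carried from one core to the other in this series with its effect intact, as the two steps run in opposite directions and lie far apart: the same change on two cores in this assay, an at least 27-fold lower number (1.43 log units; beyond the scatter) from compound 1 to compound 2 and a 2.2-fold higher number (0.33 log units; beyond the scatter) from compound 3 to compound 4, at least 58-fold (1.76 log units) apart, beyond the scatter of two such steps The earlier step is measured against a limit, so its full size stays unknown, and two pairs do not show why the cores differ or what the change would do on a third core: the limit of > 100 mg/kg in this assay, at which 1 of the 4 values shown sits.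

No compound shown alters the core one part at a time, so it remains open which part of the core goes with the different outcome. Also open, on these data alone, is how another amine, such as pyrrolidin-1-yl, or a longer chain would behave on each core.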